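The source may report more compounds than this note shows. Statements on the series, on what has been measured and on what is new or still open speak of the compounds shown alone.

Within the data shown here, the three compounds measured so far share one core and differ only at the amine-bearing chain. Compound 1 `CC(C)C[C@H](N)CN(C(=O)[C@@H]1C[C@H]1c1ccccc1)c1ccc(-c2ccccc2)cc1` gives in a functional assay for agonist activity at G protein-coupled receptor 88 (Homo sapiens), read by HTRF and cAMP accumulation (on this read-out lower numbers stand for an effect already at smaller amounts and higher numbers for an effect only at larger amounts of compound), a value of 880 nM, the highest of the three numbers recorded. Compound 2 `CN[C@@H](CC(C)C)CN(C(=O)[C@@H]1C[C@H]1c1ccccc1)c1ccc(-c2ccccc2)cc1` gives 2 nM in this assay, and compound 3 `CC(C)CCNCCN(C(=O)[C@@H]1C[C@H]1c1ccccc1)c1ccc(-c2ccccc2)cc1` gives 5.1 nM. The step from compound 1 to compound 2 is a 440-fold lower number from compound 1 to compound 2 (2.64 log units; beyond the scatter), the step from compound 1 to compound 3 is a 170-fold lower number from compound 1 to compound 3 (2.24 log units; beyond the scatter), and between the two stronger compounds there is a 2.6-fold higher number from compound 2 to compound 3 (0.41 log units; beyond the scatter). All three steps concern the chain that carries the amine.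

Compound 4 `CC(C)C[C@H](N)CN(C(=O)[C@@H]1C[C@H]1c1ccccc1)c1ccc(-c2ccsc2)cc1` differs from compound 1 at a different place: thiophen-3-yl in place of phenyl on an aromatic carbon. Among the measured compounds shown here, none of the measured steps touches this aromatic end of the core, so they give no guide to the direction or size of this change; they only show that the chain, not the ring, has so far moved the numbers. Compound 4 is therefore expected to remain near compound 1, with the step of a 1.0-fold higher number from compound 1 to compound 4 (0.01 log units; within the scatter) expected to stay within the scatter. The value of compound 4 in this assay is estimated at 900 nM, with a range from 300 nM to 2700 nM.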

Compound 4, half-maximal effective concentration: 1200 nM
Estimate against measurement, compound 4: 1.3-fold (0.12 log units) below; measured number inside the range.
By their numbers in this assay, from the lowest: compound 2; then compound 3; then compounds 1 and 4 (each within the scatter of the next).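

At the aromatic end of the shared core, on an aromatic carbon para to a large group, this assay records a 1.4-fold higher number from compound 1 to compound 4 (0.13 log units; within the scatter) when thiophen-3-yl replaces phenyl. Among these compounds, all the earlier steps lay on the amine-bearing chain, so this is the first reading from this end of the molecule, and it shows that a five-membered aromatic ring with 1 hetero atom can stand in for a six-membered aromatic ring of carbon only without a change beyond the scatter, at least with the chain of compound 1 in place. No supporting information is available that would explain this outcome.

The compounds shown leave open whether the same exchange would also stay within the scatter with the chains of compound 2 or compound 3, whose numbers are far lower than that of compound 1. They also leave open how this position would respond to a group of another kind, such as thiophen-2-yl, pyridin-3-yl, a carboxylic acid or a simple amine, so the reading so far covers this single ring exchange alone.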